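The source may report more compounds than this note shows. Statements on the series, on what has been measured and on what is new or still open speak of the compounds shown alone.

Measured compounds:
- compound 1, `COc1ccc(C2=NN(C(=O)c3ccc(C)nc3)C(c3ccc(OC)cc3)C2)cc1`: 4930 nM
- compound 2, `COc1ccc(C2=NN(C(=O)c3ccc(C)nc3Cl)C(c3ccc(OCc4ccccc4)cc3)C2)cc1`: 10500 nM

Of the compounds shown here, two have been measured in a functional assay on WM 266-4 cells (Homo sapiens) for antiproliferative activity, read by MTT assay, with a stated time of 24 h (a higher number here means a weaker inhibitor of growth, a lower number a stronger inhibitor of growth), so far. Compound 1 gives 4930 nM in this assay. Compound 2 gives 10500 nM in this assay, which is the highest of the two numbers; compound 1 lies lower, and the gap between the two is beyond the usual scatter. Within the data shown here, the two compounds differ in more than one place, so no single step can be read from them; their two values show only that compound 2 sits at the weaker end of what is known.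

The next compound, compound 3, is `COc1ccc(C2=NN(C(=O)c3ccc(C)nc3)C(c3ccc(OCc4ccccc4)cc3)C2)cc1`. It differs from compound 2 in one place: hydrogen in place of chloro on an aromatic carbon. Among the measured compounds shown here, no measured pair shows this change on its own, so the size of its effect is unknown. The account here expects a modest change from compound 2 to compound 3 in this assay, if any, most likely toward a lower number, but one that could well stay within the scatter; the expected step is a 1.5-fold lower number from compound 2 to compound 3 (0.18 log units; within the scatter). Compound 3 is therefore estimated at 7000 nM in this assay, with a range from 2500 nM to 20000 nM.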

Compound 3, concentration for 50% growth inhibition: 7950 nM
For compound 3 the middle estimate is 1.1-fold (0.06 log units) below the measured one; measured number inside the range.
By their numbers in this assay, from the lowest: compounds 1, 3 and 2 (each within the scatter of the next, the first and the last beyond it).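

In this assay, hydrogen in place of chloro on the aromatic carbon next to the ring nitrogen, which turns 2-chloro-6-methylpyridin-3-yl into 6-methylpyridin-3-yl, gives a 1.3-fold lower number from compound 2 to compound 3 (0.12 log units; within the scatter) and so leaves the number within the scatter at this position. Compound 3 also supplies a one-place comparison for the other end of the molecule, where phenyl in place of hydrogen on a saturated chain carbon bound to an oxygen on an aromatic ring gives a 1.6-fold higher number from compound 1 to compound 3 (0.21 log units; within the scatter) in the same assay, so neither single change, taken alone, shifts growth inhibition beyond the scatter. No measurement on these compounds speaks to what lies behind either step.

Going by these compounds, whether another group at the position next to the ring nitrogen, such as a methoxy, a nitrile or an amine, would move the number beyond the scatter remains open. Also open, on these data alone, is whether a carboxylic acid or a longer chain in place of the phenyl on the chain carbon bound to the oxygen would do so, and whether either step would hold in other cell lines.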